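Phenyl in place of methyl on the amide of compound 1

A few compounds are considered here, and "the series" means these few. Any claim that something is new, unique, unknown or untested is made for them only; others in the source may bear on it.

Compound 1 `CC(=O)Nc1ccn([C@@H]2CO[C@H](CO)O2)c(=O)n1` gives 10700 nM in a functional assay on SW1573 cells (Homo sapiens) for cytotoxicity, read by sulforhodamine B assay, with a stated time of 72 h (on this read-out higher numbers stand for weaker inhibition and lower numbers for stronger inhibition), and stands highest of the two numbers shown. Compound 2 `CCCCCCCCCCCCCCCC(=O)Nc1ccn([C@@H]2CO[C@H](CO)O2)c(=O)n1` gives 20 nM in the same assay, a far lower number. Compound 3 `O=C(Nc1ccn([C@@H]2CO[C@H](CO)O2)c(=O)n1)c1ccccc1` has not been measured; it differs from compound 1 by phenyl in place of methyl on a carbonyl carbon. Going by the values given here, with no measured step of this kind, a lowering of moderate size is expected from compound 1 to compound 3, estimated as a 3.6-fold lower number from compound 1 to compound 3 (0.55 log units; beyond the scatter), since compound 2 shows that a larger acyl group gives 20 nM. Compound 3 is therefore expected at 3000 nM, within 700 nM to 12000 nM.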

Compound 3, half-maximal inhibitory concentration: 13700 nM
Beside the measured number, compound 3's estimate is 4.6-fold (0.66 log units) below it, and the stated range ends below it.
By their numbers in this assay, from the lowest: compound 2; then compounds 1 and 3 (each within the scatter of the next).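

In this assay, phenyl in place of methyl on a carbonyl carbon gives a 1.3-fold higher number from compound 1 to compound 3 (0.11 log units; within the scatter). A ring on this carbonyl therefore does not reproduce the low number of the long chain in compound 2, at 20 nM, so more heavy atoms here are not enough on their own. Nothing at hand bears on the reason for this result. Still open, from the compounds shown here alone, is how the number follows chain length between the methyl and the long chain, as with a hexyl or decyl chain on the same carbonyl. Also open, going by these compounds, is whether a phenyl carrying a long alkyl chain would behave like the chain or like the ring.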